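Chloro back in place of methylsulfonyl: expectations for compound 4

The source may hold more compounds than are shown below. What is called first, only, known or untested is meant among the compounds shown, and "the series" means these compounds.

In a functional assay on HCT-116 cells (Homo sapiens) for antiproliferative activity, read by MTT assay (a lower number here means a stronger inhibitor, a higher number a weaker inhibitor), compound 3 `Cn1c(=O)c(=O)n(C2CCCC2)c2nc(N/N=C/c3ccc(S(C)(=O)=O)cc3)ncc21` gives 86600 nM, the higher of the two numeric values in the series. Compound 2 `Cn1c(=O)c(=O)n(C2CCCC2)c2nc(N/N=C/c3ccc(Cl)cc3)ncc21` gives 9810 nM. Compound 1 `Cc1cccc(/C=N/Nc2ncc3c(n2)n(C2CCCC2)c(=O)c(=O)n3C)c1` gives > 100000 nM, which is a limit of the assay and not a number.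

Compound 4 `Cn1c(=O)c(=O)n(C2CCCC2)c2nc(N/N=C/c3cccc(Cl)c3Cl)ncc21` has 2,3-dichlorophenyl in place of the 4-(methylsulfonyl)phenyl of compound 3, on a carbon with a double bond to nitrogen: 2,3-dichlorophenyl in place of 4-(methylsulfonyl)phenyl on a carbon with a double bond to nitrogen.

For the measured compounds named here, three measured steps bear on this change. The closest is an 8.8-fold higher number from compound 2 to compound 3 (0.95 log units; beyond the scatter), with methylsulfonyl in place of chloro on an aromatic carbon. The step of an at least 10-fold lower number from compound 1 to compound 2 (1.00 log units; beyond the scatter) also favours the chloro-bearing aryl group. The step of an at least 1.1-fold lower number from compound 1 to compound 3 (0.06 log units; that floor lies within the scatter) starts from a limit, and its floor lies within the scatter, so it adds little. Going by the values given here, no measured compound carries 2,3-dichlorophenyl, so the transfer from 4-chlorophenyl is uncertain.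

A lower number is expected for the new compound because an 8.8-fold higher number from compound 2 to compound 3 (0.95 log units; beyond the scatter) shows the cost of methylsulfonyl against chloro. The expected size in this assay is a 5.8-fold lower number from compound 3 to compound 4 (0.76 log units; beyond the scatter), slightly smaller than that measured gap. Compound 4 is estimated at 15000 nM, with an expected range of 4000 nM to 60000 nM.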

Compound 4, half-maximal inhibitory concentration: 26400 nM
The estimate for compound 4 lay 1.8-fold (0.25 log units) below the measured number, within the range that was stated.
By their numbers in this assay, from the lowest: compound 2; then compound 4; then compound 3. At a limit, above all of these: compound 1.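

In this assay, a second chlorine-bearing aryl group on this carbon with a double bond to nitrogen also gives a lower number than 4-(methylsulfonyl)phenyl (a 3.3-fold lower number from compound 3 to compound 4 (0.52 log units; beyond the scatter)), so that advantage is not confined to 4-chlorophenyl. The two chlorine-bearing groups are not interchangeable, however (a 2.7-fold higher number from compound 2 to compound 4 (0.43 log units; beyond the scatter)), and 4-chlorophenyl keeps the lowest number among the compounds shown, with 2,3-dichlorophenyl falling between it and 4-(methylsulfonyl)phenyl. Compound 1 stands at a limit, not a number, so its step to 2,3-dichlorophenyl (an at least 3.7-fold lower number from compound 1 to compound 4 (0.57 log units; beyond the scatter)) gives only a floor: the limit of > 100000 nM in this assay, at which 1 of the 4 values shown sits.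

Whether the gap between 4-chlorophenyl and 2,3-dichlorophenyl follows the number of chlorines or their placement stays open, since no compound shown separates the two. Also open, as far as these compounds go, is how this assay would read a phenyl group carrying an amine or a carboxylic acid at this place, or a saturated ring such as cyclohexyl in place of the aryl group.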